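Acyl chain extension in a methoxyphenylbutyl amide series

A few compounds are considered here, and "the series" means these few. Any claim that something is new, unique, unknown or untested is made for them only; others in the source may bear on it.

The two measured compounds are alkanamides carrying a methoxyphenyl tail on the amine side. Compound 1 `CCCCC(=O)NCCCc1ccccc1OC` in an assay for binding affinity to melatonin receptor (Gallus gallus) (on this read-out higher numbers stand for weaker inhibition and lower numbers for stronger inhibition), gives only the limit > 100000 nM and no number. Among the compounds with values here, compound 2 `CCC(=O)NCCCCc1ccc(OC)cc1` in this assay gives 1400 nM, the only real number in the set so far; the remaining entry is the limit of > 100000 nM in this assay, at which 1 of the 2 values shown sits. Compound 3 `CCCCC(=O)NCCCCc1ccc(OC)cc1` remains to be measured in this assay. It differs from compound 2 by ethyl in place of hydrogen on a saturated chain carbon, two bonds along the chain from a carbonyl carbon; read one bond further out the change is propanoyl to butylcarbonyl. Within the data shown here, no step between measured compounds allows this change to be weighed directly. The expectation is a small loss of affinity, close to the edge of the scatter, the step from compound 2 to compound 3 being estimated as a 1.8-fold higher number from compound 2 to compound 3 (0.25 log units; within the scatter). For compound 3 the estimated value in this assay is 2500 nM, with a range from 600 nM to 12000 nM.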

Compound 3, inhibition constant: 7000 nM
Compound 3: middle estimate off by 2.8-fold (0.45 log units), on the low side; low and high end bracket the measured number.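

In this assay the acyl chain proves sensitive to length: with the rest of the structure unchanged, ethyl in place of hydrogen on a saturated chain carbon, two bonds along the chain from a carbonyl carbon, gives a 5.0-fold higher number from compound 2 to compound 3 (0.70 log units; beyond the scatter). Within the data shown here, this is the first step that can be read directly, and it shows that going from propanoyl to butylcarbonyl weakens binding beyond the scatter while compound 3 still returns a real number. Nothing at hand accounts for the size of this step.

From the compounds shown here alone, whether an acetyl group or a longer chain would continue this direction remains open. Among these compounds, compound 1 gives > 100000 nM, which is a limit, and it differs from the other compounds in more than one place, so no step to it can be read.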